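The source may report more compounds than this note shows. Statements on the series, on what has been measured and on what is new or still open speak of the compounds shown alone.

Compound 2 `C[C@H]1CN(c2ccc(C#CC(C)(O)c3nccs3)cc2Nc2ncnc3[nH]ccc23)CCN1` stands at the higher of the two numbers obtained so far in an assay for inhibition of mitogen-activated protein kinase kinase kinase 14 (Homo sapiens), read by luminescence and ADP-Glo, with a stated time of 120 min, in the presence of a further agent that is not named here; on this read-out lower numbers stand for stronger inhibition and higher numbers for weaker inhibition: compound 2 gives 69.2 nM, whereas compound 1 `CN(C)c1ccc(C#CC(C)(O)c2nccs2)cc1Nc1ncnc2[nH]ccc12` gives 22.5 nM. Among the measured compounds shown here, the only measured step is a 3.1-fold higher number from compound 1 to compound 2 (0.49 log units; beyond the scatter), which exchanged a dimethylamino group for the 3-methylpiperazin-1-yl group. Compound 3 `CN1CCN(c2ccc(C#CC(C)(O)c3nccs3)cc2Nc2ncnc3[nH]ccc23)CC1` has not yet been measured in this assay. It differs from compound 2 by 4-methylpiperazin-1-yl in place of 3-methylpiperazin-1-yl on an aromatic carbon; the two compounds contain the same atoms joined differently, so the group that leaves brings one hydrogen-bond donor and the group that enters brings none. For the measured compounds named here, no measured step covers this rearrangement, because a 3.1-fold higher number from compound 1 to compound 2 (0.49 log units; beyond the scatter) concerns a different exchange, and the data therefore give no direct guide to its size or direction. The expectation is a small step, a 1.5-fold lower number from compound 2 to compound 3 (0.19 log units; within the scatter), which may well fall within the scatter of repeated measurements. Compound 3 is estimated to give 45 nM, with a likely range from 15 nM to 140 nM.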

Compound 3, half-maximal inhibitory concentration: 78.3 nM
Beside the measured number, compound 3's estimate is 1.7-fold (0.24 log units) below it; measured number inside the range.
By their numbers in this assay, from the lowest: compound 1; then compounds 2 and 3 (each within the scatter of the next).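

Moving the methyl group within the piperazine ring, so that 3-methylpiperazin-1-yl becomes 4-methylpiperazin-1-yl, removes the hydrogen-bond donor and the defined stereocentre, yet in this assay it gives only a 1.1-fold higher number from compound 2 to compound 3 (0.05 log units; within the scatter); at this position, on this read-out, the two piperazine groups cannot be told apart. The rise seen with the first piperazine therefore recurs with the second, since dimethylamino to 4-methylpiperazin-1-yl gives a 3.5-fold higher number from compound 1 to compound 3 (0.54 log units; beyond the scatter), so among these three compounds the higher number goes with both piperazine groups and not with one particular placement of the methyl group. No measurement here offers an explanation for either the rise or the lack of a difference between the two piperazine groups.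

The compounds shown leave open whether the higher number follows from the piperazine ring itself or simply from a larger group at this place, a question that a morpholin-4-yl or piperidin-1-yl group would help to settle. They also leave open how the mirror-image form of the 3-methylpiperazin-1-yl group, or an unsubstituted piperazin-1-yl group, would compare.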